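This account rests on a few compounds, and the source may have more. Where it says the series, first, only, none or still open, it means among the compounds named here.

Working notes on the series.

Compound 1 `CSc1ccc(/C=C(\C(=O)c2ccc(Br)cc2)S(=O)(=O)Cc2ccc(F)cc2)cc1` carries a bromine-bearing benzoyl and a fluorine-bearing benzylsulfonyl on the double bond; in a functional assay on DU-145 cells (Homo sapiens) for inhibition, read by trypan blue exclusion, with a stated time of 96 h (on this read-out higher numbers stand for weaker inhibition of growth and lower numbers for stronger inhibition of growth), compound 1 gives 50000 nM, the highest number of the three measured, and its gap to each of the other two is beyond the scatter. Compound 2 `CSc1ccc(/C=C(\C(=O)c2ccc(Cl)cc2)S(=O)(=O)Cc2ccc(C)cc2)cc1`, with chlorine and a methyl in the corresponding positions, gives 10000 nM in this assay. How the cores of compound 1 and compound 2 differ is not broken down here. Compound 3 `Cc1ccc(CS(=O)(=O)/C(=C/c2cc(C)cc(C)c2)C(=O)c2ccc(Cl)cc2)cc1` gives 10000 nM in this assay. The change 3,5-dimethylphenyl in place of 4-(methylsulfanyl)phenyl on a double-bonded chain carbon bound to a double-bonded chain carbon produced no change at the digits printed from compound 2 to compound 3 (within the scatter).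

Compound 4 `Cc1cc(C)cc(/C=C(\C(=O)c2ccc(Br)cc2)S(=O)(=O)Cc2ccc(F)cc2)c1` differs from compound 1 by 3,5-dimethylphenyl in place of 4-(methylsulfanyl)phenyl on a double-bonded chain carbon bound to a double-bonded chain carbon, the same change as from compound 2 to compound 3, at the same place. Since that change gave no change at the digits printed from compound 2 to compound 3 (within the scatter), the step expected here is no change at the digits printed from compound 1 to compound 4 (within the scatter), resting on that single precedent, with the caveat that the two cores around the change differ and that difference is not broken down. Compound 4 is therefore estimated at 50000 nM in this assay, between 20000 nM and 120000 nM.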

Compound 4, concentration for 50% growth inhibition: 10000 nM
For compound 4 the middle estimate is 5.0-fold (0.70 log units) above the measured one; measured number outside the range, below it.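

In this assay, 3,5-dimethylphenyl in place of 4-(methylsulfanyl)phenyl gives a 5.0-fold lower number from compound 1 to compound 4 (0.70 log units; beyond the scatter), so the change does not carry over with the same size from one core to the other: the same change on two cores in this assay, no change at the digits printed (within the scatter) from compound 2 to compound 3 and a 5.0-fold lower number (0.70 log units; beyond the scatter) from compound 1 to compound 4, 5.0-fold (0.70 log units) apart, beyond the scatter of two such steps. This shows that, in these two pairs, the size of the step depends on the core that carries the change, so the result on one core is a poor guide to the result on the other. It does not show which part of the core is responsible, since the cores of compound 1 and compound 2 differ at both the benzoyl and the benzylsulfonyl groups, and two pairs establish no rule for the wider series.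

Still open, going by these compounds, is whether the bromine and fluorine or the chlorine and methyl account for the gap, which would take compounds differing at only one of those places. Also open, on these data alone, is how an amine or a carboxylic acid would behave on the double-bonded chain carbon in place of either aromatic group.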